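This account rests on a few compounds, and the source may have more. Where it says the series, first, only, none or still open, it means among the compounds named here.

In a functional assay on OVCAR-3 cells (Homo sapiens) for cytotoxicity, read by sulforhodamine B assay, with a stated time of 48 h (a higher number here means a weaker inhibitor of growth, a lower number a stronger inhibitor of growth), three compounds have been measured: compound 1 `ClCc1cccc(Cn2cnc3c(Cl)ncnc32)c1` gives 1620 nM, compound 2 `ClCc1ccc(Cn2cnc3nc(Cl)nc(Cl)c32)cc1` gives 300 nM, and compound 3 `ClCc1cccc(Cn2cnc3c(Cl)nc(Cl)nc32)c1` gives 1580 nM.

Compound 3 and compound 1 differ by one change, (hydrogen in place of chloro on an aromatic carbon), and this change made a step of a 1.0-fold higher number from compound 3 to compound 1 (0.01 log units; within the scatter). Compound 2 and compound 3 have the same atoms joined differently; the difference between the two cores is not broken down here. Compound 2 has the lowest number of the three, with compound 3 and compound 1 both well beyond the scatter from it.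

Compound 4 `ClCc1ccc(Cn2cnc3ncnc(Cl)c32)cc1` has not yet been measured. It differs from compound 2 by hydrogen in place of chloro on an aromatic carbon, the same change that was made from compound 3 to compound 1. Because that earlier step was a 1.0-fold higher number from compound 3 to compound 1 (0.01 log units; within the scatter), a step of about a 1.0-fold higher number from compound 2 to compound 4 (0.01 log units; within the scatter) is expected from compound 2 to compound 4 in this assay. On that basis compound 4 is estimated at 310 nM, with a range from 150 nM to 700 nM.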

Compound 4, concentration for 50% growth inhibition: 1810 nM
For compound 4 the middle estimate is 5.8-fold (0.77 log units) below the measured one; measured number above the stated range.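

In this assay, hydrogen in place of chloro on an aromatic carbon gives a step of a 6.0-fold higher number from compound 2 to compound 4 (0.78 log units; beyond the scatter), so the change does not carry over unchanged from one core to the other: the same change on two cores in this assay, a 1.0-fold higher number (0.01 log units; within the scatter) from compound 3 to compound 1 and a 6.0-fold higher number (0.78 log units; beyond the scatter) from compound 2 to compound 4, 5.9-fold (0.77 log units) apart, beyond the scatter of two such steps

Among the compounds shown here, the step seen on one core was therefore no guide to the step on the other, at least for these two pairs. Two pairs do not show why the cores differ, nor how the change would behave on any further core.

As far as these compounds go, what an amine or a methoxy group would do on that same aromatic carbon, on either core, remains open. So does the effect of a methyl group in place of the chloromethyl group.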